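The compounds below may be only part of what the source reports. "The series", "measured", "known", "first", "only" and "open" are said of these compounds alone.

The series shares one core. Compound 1 `CCCCSC(=S)C1=C(Nc2ccc(Cl)cc2Cl)CC(C)(C)CC1=O` in a functional assay on PBMC cells (Homo sapiens) for inhibition, read by thymidine incorporation, with a stated time of 72 h (a higher number here means a weaker inhibitor, a lower number a stronger inhibitor), gives only a limit of the assay, > 50 ug/mL, and no number. Compound 2 `CC1(C)CC(=O)C(C(=S)SCc2ccccc2)=C(Nc2ccc(Cl)cc2Cl)C1`, which carries phenyl in place of propyl on a saturated chain carbon bound to a sulfur, gives in this assay likewise only a limit, > 50 ug/mL. Compound 3 `CCCCSC(=S)C1=C(Nc2ccc(Cl)cc2)CC(C)(C)CC1=O`, with hydrogen in place of chloro on an aromatic carbon, gives in this assay again only a limit, > 50 ug/mL. Both measured steps are therefore unreadable: a step that the two limits leave unreadable from compound 1 to compound 2 and a step that the two limits leave unreadable from compound 1 to compound 3. Since the limit of > 50 ug/mL in this assay, at which 3 of the 3 values shown sit, holds for every value shown, compound 3 stands at the limit with no number that would place it against the others.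

Compound 4 `CC1(C)CC(=O)C(C(=S)SCCO)=C(Nc2ccc(Cl)cc2)C1` differs from compound 3 by hydroxy in place of ethyl on a saturated chain carbon, two bonds along the chain from a sulfur. Among the compounds with values here, no measured step touches the saturated chain carbon two bonds along the chain from a sulfur, and the two steps that exist give no size; they carry nothing to compound 4 beyond the fact that every change tried so far in this assay stayed at the limit. The expectation for compound 4 in this assay is therefore again a weak result, estimated at 60 ug/mL within 15 ug/mL to 200 ug/mL. The expected step is a step that the limit leaves unreadable from compound 3 to compound 4, most likely read once more only as a limit.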

Compound 4, half-maximal inhibitory concentration: 21 ug/mL
Beside the measured number, compound 4's estimate is 2.9-fold (0.46 log units) above it; measured number inside the range.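

In this assay, within the data shown here, hydroxy in place of ethyl on a saturated chain carbon, two bonds along the chain from a sulfur, gives an at least 2.3-fold lower number from compound 3 to compound 4 (0.37 log units; beyond the scatter), the only readable step so far. This shows that the read-out responds to a change in the sulfur-bound chain: butylsulfanyl to (2-hydroxyethyl)sulfanyl moves the series off the limit, while the steps from compound 1 to compound 2 and from compound 1 to compound 3 cannot be read. Among these compounds, the true size of the step also stays open, since the value of compound 3 is only a limit, and compound 4 is the only compound with a number, the others sitting at: the limit of > 50 ug/mL in this assay, at which 3 of the 4 values shown sit.

The compounds shown do not separate the hydroxy group itself from the shortening of the chain, so a methoxy group, an amine or a carboxylic acid at the same chain carbon, or a longer chain such as 3-hydroxypropyl, would each bear on that question. Also open, from the compounds shown here alone, is whether the 2-hydroxyethyl chain gives a number on the dichlorinated aromatic ring of compound 1.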